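The compounds below may be only part of what the source reports. "The series", "measured", "known", "first", "only" and "open" are said of these compounds alone.

Measured compounds:
Compound 1, `Nc1cc(N)c2nc(-c3ccccc3)c(Oc3ccc(Cl)c(Cl)c3)nc2c1`: 9770 nM
Compound 2, `COc1cc(CNc2nc3cc(N)cc(N)c3nc2-c2ccccc2)cc(OC)c1OC`: 1550 nM

In a functional assay on SW-620 cells (Homo sapiens) for inhibition, read by sulforhodamine B assay, with a stated time of 48 h (a higher number here means a weaker inhibitor of growth, a lower number a stronger inhibitor of growth), compound 1 gives 9770 nM, the higher of the two numbers shown. Compound 2 gives 1550 nM in this assay, and the gap between the two values lies beyond the usual scatter of repeated measurements. Compound 3, `Nc1cc(N)c2nc(-c3ccccc3)c(Oc3ccc(F)cc3)nc2c1`, is not yet measured; it differs from compound 1 in one place, with 4-fluorophenyl in place of 3,4-dichlorophenyl on an oxygen on an aromatic ring. Among the measured compounds shown here, no pair of measured compounds shows this kind of exchange, so there is no measured step on which to rest an expectation of its size, and the two measured compounds differ in a different part of the structure. The step is therefore expected to be small, a 1.2-fold higher number from compound 1 to compound 3 (0.09 log units; within the scatter), with no clear direction beyond the scatter. Compound 3 is expected to give about 12000 nM in this assay, within a range from 4000 nM to 40000 nM.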

Compound 3, concentration for 50% growth inhibition: 19500 nM
For compound 3 the middle estimate is 1.6-fold (0.21 log units) below the measured one; low and high end bracket the measured number.
By their numbers in this assay, from the lowest: compound 2; then compounds 1 and 3 (each within the scatter of the next).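

In this assay, among the compounds shown here, the exchange of 3,4-dichlorophenyl for 4-fluorophenyl on an oxygen on an aromatic ring gives the first measured step at this place, and it amounts to a 2.0-fold higher number from compound 1 to compound 3 (0.30 log units; within the scatter). The two chlorine atoms can therefore give way to a single fluorine with no shift that can be told apart from repeat measurement, so this step gives no sign that growth inhibition here depends on which of these two halogenated phenyl groups is present. Nothing measured here accounts for the size of this step.

From the compounds shown here alone, the step alters the chlorine atoms and the fluorine together, so what each contributes alone stays open. Also open, going by these compounds, is whether this place needs a halogenated phenyl group at all, or would accept an unsubstituted phenyl, a pyridine ring or a short alkyl chain on that oxygen.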